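Shortening a carboxylic acid chain on two related cores

This account rests on a few compounds, and the source may have more. Where it says the series, first, only, none or still open, it means among the compounds named here.

Of the compounds shown here, three have been measured in a functional assay on a cell-free system (Platelet, plasma, Homo sapiens) for inhibition (on this read-out higher numbers stand for weaker inhibition and lower numbers for stronger inhibition), and a fourth awaits its number. Compound 1 `O=C(O)CN1Cc2ccc(NC(=O)c3ccc4c(c3)CNCC4)cc2C1=O` and compound 2 `O=C(O)CCCN1Cc2ccc(NC(=O)c3ccc4c(c3)CNCC4)cc2C1=O` share one core; compound 3 `O=C(O)CCCN1Cc2ccc(NC(=O)CC3CCNCC3)cc2C1=O` and compound 4 `O=C(O)CN1Cc2ccc(NC(=O)CC3CCNCC3)cc2C1=O` share another. How the two cores differ is not broken down here.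

On the first core, compound 2 gives 330000 nM and compound 1 gives 120000 nM. The change from compound 2 to compound 1 is carboxy in place of 2-carboxyethyl on a saturated chain carbon bound to an amide-type nitrogen in a ring, and it produced a 2.8-fold lower number from compound 2 to compound 1 (0.44 log units; beyond the scatter). On the second core, compound 3 gives 1800 nM, a far lower number than either compound 1 or compound 2.

Compound 4 is related to compound 3 by the same change: carboxy in place of 2-carboxyethyl on a saturated chain carbon bound to an amide-type nitrogen in a ring. For the measured compounds named here, the single earlier example of this change moved the number only modestly, and the step from compound 3 to compound 4 is expected to be of a similar size, a 2.6-fold lower number from compound 3 to compound 4 (0.41 log units; beyond the scatter), because compound 2 to compound 1 gave a 2.8-fold lower number from compound 2 to compound 1 (0.44 log units; beyond the scatter). That expectation rests on one pair only, on a different core, so it carries real uncertainty.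

For compound 4 in this assay the estimate is 700 nM, with a likely range from 250 nM to 2500 nM.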

Compound 4, half-maximal inhibitory concentration: 51000 nM
Estimate against measurement, compound 4: 73-fold (1.86 log units) below, outside the stated range (above it).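

On the core of compound 3, putting carboxy in place of 2-carboxyethyl gave a 28-fold higher number from compound 3 to compound 4 (1.45 log units; beyond the scatter) in this assay, which means much weaker inhibition and runs opposite to the small gain seen on the other core. So this change did not carry from one core to the other, either in direction or in size: the same change on two cores in this assay, a 2.8-fold lower number (0.44 log units; beyond the scatter) from compound 2 to compound 1 and a 28-fold higher number (1.45 log units; beyond the scatter) from compound 3 to compound 4, 78-fold (1.89 log units) apart, beyond the scatter of two such steps

This shows that, for these two pairs, the effect of shortening the chain depended on the core it was attached to, so a result on one core was a poor guide to the other, but two pairs give no general rule for a third core and do not explain why the cores responded differently.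

The compounds shown cover only the 3-carboxypropyl and carboxymethyl chains, so it remains open how inhibition changes on each core with a chain of intermediate length or a longer chain ending in a carboxylic acid. Going by these compounds, it is also open whether the carboxylic acid itself matters on either core, a question that an ester or a primary amide in its place could help answer.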